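Cyclopropylsulfamoyl in place of isopropylsulfonyl: an expected clearance

The compounds below may be only part of what the source reports. "The series", "measured", "known", "first", "only" and "open" are said of these compounds alone.

Of the compounds shown here, three sharing one core have been measured in an ADME assay on microsomes from liver (Homo sapiens) for metabolic stability, read by LC-MS, with a stated time of 40 min, tested at 0.5 uM; a higher number here means faster removal of the compound, a lower number slower removal. Compound 1 `CC(C)(CO)S(=O)(=O)c1cccc(NC(=O)c2cccnc2N2CCC3(CC2)CC3)c1` gives 154 mL.min-1.g-1, compound 2 `O=C(Nc1cccc(S(=O)(=O)C2COC2)c1)c1cccnc1N1CCC2(CC1)CC2` gives 183 mL.min-1.g-1, and compound 3 `CC(C)S(=O)(=O)c1cccc(NC(=O)c2cccnc2N2CCC3(CC2)CC3)c1` gives 375 mL.min-1.g-1. Compound 3 stands highest of the three numbers: the nearest is compound 2, seen in the step of a 2.0-fold higher number from compound 2 to compound 3 (0.31 log units; beyond the scatter), and the furthest is compound 1, seen in a 2.4-fold higher number from compound 1 to compound 3 (0.39 log units; beyond the scatter). The step of a 1.2-fold higher number from compound 1 to compound 2 (0.07 log units; within the scatter) lies within the scatter.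

Compound 4 `O=C(Nc1cccc(S(=O)(=O)NC2CC2)c1)c1cccnc1N1CCC2(CC1)CC2` has not yet been measured. It differs from compound 3 as follows: cyclopropylamino in place of isopropyl on a sulfonyl sulfur.

Among the measured compounds shown here, two measured steps bear on this change, since both end at compound 3 and replace a group on the sulfonyl sulfur: a 2.0-fold higher number from compound 2 to compound 3 (0.31 log units; beyond the scatter) and a 2.4-fold higher number from compound 1 to compound 3 (0.39 log units; beyond the scatter). Each was a modest step upward, placing compound 3 above the two compounds whose sulfonyl substituents carry an oxygen or a hydroxymethyl. Compound 4 brings a cyclopropylamino group with one hydrogen-bond donor onto the same sulfur, so compound 4 is expected to move modestly downward from compound 3, a step of about a 2.1-fold lower number from compound 3 to compound 4 (0.32 log units; beyond the scatter) in this assay.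

The estimate for compound 4 in this assay is 180 mL.min-1.g-1, with a range from 95 mL.min-1.g-1 to 340 mL.min-1.g-1.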

Compound 4, intrinsic clearance in microsomes: > 399 mL.min-1.g-1
Compound 4: only a limit was reported (the forecaster's own chance of this, stated with the estimate: 5%); middle value at least 2.2-fold (0.34 log units) away from the limit.
By their numbers in this assay, from the lowest: compounds 1 and 2 (each within the scatter of the next); then compound 3. At a limit, above all of these: compound 4.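

In this assay compound 4 gives > 399 mL.min-1.g-1, which is a limit of the assay and not a number, so its place is known from one side only: the limit of > 399 mL.min-1.g-1 in this assay, at which 1 of the 4 values shown sits. Among the compounds shown here, the steps of an at least 2.1-fold higher number from compound 2 to compound 4 (0.33 log units; beyond the scatter) and an at least 2.5-fold higher number from compound 1 to compound 4 (0.41 log units; beyond the scatter) show that, among the groups on this sulfonyl sulfur, cyclopropylamino does not join oxetan-3-yl and 1-(hydroxymethyl)-1-methylethyl at the lower end, so the earlier steps down from isopropyl do not extend to every group carrying an atom other than carbon. Going by these compounds, the step of an at least 1.0-fold higher number from compound 3 to compound 4 (0.02 log units; that floor lies within the scatter) has a floor within the scatter, so this change from isopropyl to cyclopropylamino, with its added ring and hydrogen-bond donor, gave no lowering of the number, though the true size of any rise stays unknown.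

On these data alone, how far compound 4 lies past its limit remains open, and with it whether this change raises the number at all. Also open, as far as these compounds go, is whether the ring or the nitrogen decides the outcome, which a plain cyclopropyl or a dimethylamino group on the same sulfur could separate.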